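A few compounds are considered here, and "the series" means these few. Any claim that something is new, unique, unknown or untested is made for them only; others in the source may bear on it.

Compound 1 `COC(=O)c1cccc(NC(=O)c2cccc3ccccc23)c1` gives in a physicochemical assay for solubility (on this read-out higher numbers stand for higher solubility and lower numbers for lower solubility), a value that is a limit of the assay, < 5 ug/mL. Compound 2 `COC(=O)c1ccc(NC(=O)c2cnc3ccccc3c2)cc1` likewise returns only a limit, < 5 ug/mL. Both results rest at the limit of < 5 ug/mL in this assay, at which 2 of the 2 values shown sit, so compound 1 and compound 2 cannot be told apart on this read-out. Compound 3 `NC(=O)c1cccc(NC(=O)c2cccc3ccccc23)c1` is not yet measured; against compound 1 the change is amino in place of methoxy on a carbonyl carbon. Going by the values given here, no measured step along this change exists, so only a modest rise beyond the scatter is expected, an at least 2.0-fold higher number from compound 1 to compound 3 (0.30 log units; that floor lies within the scatter). Compound 3 is accordingly estimated at 10 ug/mL, within 2 ug/mL to 40 ug/mL, with a fair chance that only a limit is again reported.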

Compound 3, solubility: 10 ug/mL
Beside the measured number, compound 3's estimate shows no gap at the digits printed; the measured number falls inside the stated range.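

Going by these compounds alone, with amino in place of methoxy on a carbonyl carbon, compound 3 is the first compound here to return a number rather than a limit in this assay. From the compounds shown here alone, the change reads as an at least 2.0-fold higher number from compound 1 to compound 3 (0.30 log units; that floor lies within the scatter) and gives only a floor, so its full size stays unknown. That floor is set by the assay limit: the limit of < 5 ug/mL in this assay, at which 2 of the 3 values shown sit.

Going by these compounds, whether a carboxylic acid or a methylamino group at the same carbonyl carbon would shift the number further stays open. Also open, on these data alone, is whether the methoxycarbonyl to carbamoyl change gives a readable number on the core of compound 2.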